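The compounds below may be only part of what the source reports. "The series", "measured", "known", "first", "only" and "open" are said of these compounds alone.

Three compounds share a small aromatic core bearing two hydroxyl groups and differ in the side chain attached to it. Compound 1 `CC(C)CCCc1nc(O)cc(O)n1` carries a branched chain ending in isopropyl. In a functional assay on HEK293 cells for agonist activity at G-protein coupled receptor 84 (Homo sapiens), read by calcium flux (a lower number here means a smaller maximal response, a higher number a larger maximal response), compound 1 gives 85.6%. Compound 2 `CCCCCCCCc1cc(O)cc(O)n1` has a straight chain on a related core, and in this assay compound 2 gives 82.6%, a number that lies within the usual scatter of the value for compound 1, so the two cannot be ranked. Compound 3 `CCc1ccc(CCc2nc(O)cc(O)n2)cc1` places an aromatic ring in its side chain, and in this assay compound 3 gives 97.4%, which is higher than compound 1 by more than the scatter. Among the three numbers, compound 1 stands second highest, with compound 2 nearest and compound 3 furthest.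

Compound 4 `CCCCCCCCc1nc(O)cc(O)n1` has not yet been measured. Compared with compound 1, the change is pentyl in place of isopropyl on a saturated chain carbon, three bonds along the chain from an aromatic carbon. The result is a straight, unbranched chain with the same core as compound 1.

Among the compounds with values here, since no pair of measured compounds differs in just one place, no measured step guides the expectation directly. Still, compound 4 is expected to show a step of a number 1.6 percentage points lower from compound 1 to compound 4 (within the scatter) from compound 1, that is, no change beyond the scatter, because compound 2 reaches 82.6% with a straight side chain on a closely related core. For compound 4 the maximal response in this assay is therefore estimated at 84%, within a range of 70% to 98%.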

Compound 4, largest response reached (reported as percent of maximum), in percent of the reference or control that the assay uses: 110%
Compound 4: the middle estimate sits 26 percentage points below what was measured; measured number above the stated range.
By their numbers in this assay, from the lowest: compounds 2 and 1 (each within the scatter of the next); then compound 3; then compound 4.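

Replacing isopropyl with pentyl on a saturated chain carbon, three bonds along the chain from an aromatic carbon, gives in this assay a step of a number 24.4 percentage points higher from compound 1 to compound 4 (beyond the scatter). Within the data shown here, the earlier compounds differed in more than one place, so this is the first direct evidence that the far end of the side chain can shift the maximal response on this core. It also shows that a change involving only carbon atoms, with no ring, no hydrogen-bond donors or acceptors and no net charge entering or leaving, is enough to move the response beyond the usual scatter, yet nothing available explains why the response rises with this change.

This single step alters both the length of the chain and its branching, so the contribution of each cannot be separated from the two compounds alone. From the compounds shown here alone, it also remains open whether the response would continue to rise, level off or fall with a longer chain, and whether an amine or a carboxylic acid at the far end of the chain would be tolerated at this position.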